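Replacing an aryl group with a pentyl chain

A few compounds are considered here, and "the series" means these few. Any claim that something is new, unique, unknown or untested is made for them only; others in the source may bear on it.

Within the data shown here, in a functional assay on PC-3 cells (Homo sapiens) for cytotoxicity, read by WST assay, with a stated time of 72 h (on this read-out higher numbers stand for weaker inhibition and lower numbers for stronger inhibition), compound 1 `CCOc1ccc(C2(c3ccc(O)cc3)C(=O)Nc3c2ccc(F)c3F)cc1` gives 24 nM as the only actual number in this small set. Compound 2 `CCCOc1ccc(C2(c3ccc(O)cc3)C(=O)Nc3c2ccc(F)c3F)cc1` reads > 1000 nM as a limit of the assay. Compound 3 `CCCCCOc1ccc(C2(c3ccc(O)cc3)C(=O)Nc3c2ccc(F)c3F)cc1` also reads > 1000 nM as a limit. Compound 4 `CCCCCC1(c2ccc(O)cc2)C(=O)Nc2c1ccc(F)c2F` differs from compound 1 by pentyl in place of 4-ethoxyphenyl on a saturated ring carbon with pentyl in place of 4-ethoxyphenyl on a saturated ring carbon. Among the measured compounds shown here, no measured step makes this swap, but additions to the ethoxy chain gave an at least 41-fold higher number from compound 1 to compound 2 (1.61 log units; beyond the scatter) and an at least 41-fold higher number from compound 1 to compound 3 (1.61 log units; beyond the scatter) as large steps beyond the scatter. A large step towards weaker inhibition is therefore expected, estimated as a 42-fold higher number from compound 1 to compound 4 (1.62 log units; beyond the scatter) with wide uncertainty. For compound 4 the expected value is 1000 nM in an estimated range from 100 nM to 6000 nM in this assay.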

Compound 4, half-maximal inhibitory concentration: 1.1 nM
For compound 4 the middle estimate is 910-fold (2.96 log units) above the measured one, outside the stated range (below it).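

In this assay, the 4-ethoxyphenyl group on the saturated ring carbon proves not to be needed, since pentyl can take its place and inhibition grows stronger (a 22-fold lower number from compound 1 to compound 4 (1.34 log units; beyond the scatter)). The earlier compounds shown here changed only the ethoxy chain, whereas this change shows that a group with no ring is accepted at this position. Nothing shown here gives a reason for this gain. Open, going by these compounds, is whether a shorter butyl chain, a longer heptyl chain or a pentyl chain ending in an amine would do as well at this position.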